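Cyclopropylcarbonyl in Place of a Chloropropylcarbonyl Amide

The compounds below may be only part of what the source reports. "The series", "measured", "known", "first", "only" and "open" are said of these compounds alone.

Compound 1 `N#CC1=C(N)N(c2ccc(S(N)(=O)=O)cc2)C2=C(C(=O)CCC2)C1c1ccc(Cl)cc1Cl`: 50%
Compound 2 `CC(Cl)CC(=O)NC1=C(C#N)C(c2ccc(Cl)cc2Cl)C2=C(CCCC2=O)N1c1ccc(S(N)(=O)=O)cc1`: 50%

In a functional assay on Ehrlich cells (Mus musculus) for cytotoxicity, read by trypan blue exclusion, with a stated time of 2 h, tested at 25 ug/mL (a lower number here means a weaker effect, a higher number a stronger effect of the compound at the concentration tested), compound 1 gives 50% and compound 2 gives 50%, so compound 2 stands level with compound 1. The step of no change at the digits printed from compound 1 to compound 2 (within the scatter), which put an acyl group on the amine nitrogen, moved nothing. Compound 3 `N#CC1=C(NC(=O)C2CC2)N(c2ccc(S(N)(=O)=O)cc2)C2=C(C(=O)CCC2)C1c1ccc(Cl)cc1Cl` carries the change (cyclopropyl in place of 2-chloropropyl on a carbonyl carbon). Within the data shown here, only that one step bears on it, and it was flat, so the expected step of no change at the digits printed from compound 2 to compound 3 (within the scatter) is none beyond the scatter. Compound 3 is therefore estimated at 50%, within 35% to 65%.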

Compound 3, a percentage reported as activity, at one concentration (the size of the read-out at that concentration, not a potency): 40%
Compound 3: middle estimate off by 10 percentage points, on the high side; the measured number falls inside the stated range.
By their numbers in this assay, from the lowest: compounds 3, 1 and 2 (each within the scatter of the next).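

With the cyclopropyl on the carbonyl carbon, a ring now stands where compound 2 held an open chain bearing chlorine, and in this assay that swap gives a number 10 percentage points lower from compound 2 to compound 3 (within the scatter) for this amide. Against the free amine, the new acyl group gives a number 10 percentage points lower from compound 1 to compound 3 (within the scatter) and so, like the 2-chloropropyl amide, does not separate from compound 1. Nothing available accounts for these readings.

As far as these compounds go, whether any acyl group at this amine nitrogen can move the effect beyond the scatter stays open. So does how a longer chain or an aminoalkyl group on that carbonyl carbon would read.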